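The source may hold more compounds than are shown below. What is called first, only, known or untested is meant among the compounds shown, and "the series" means these compounds.

Compound 1, `Cc1c(NC2=NCCN2)cccc1-c1ccccc1`, gives 16.2 nM in an assay on cell membranes for binding affinity to 5-hydroxytryptamine receptor 7 (Rattus norvegicus) (a lower number here means a stronger inhibitor, a higher number a weaker inhibitor), the lower of the two numbers recorded here. Compound 2, `Cc1c(NC2=NCCN2)cccc1-c1cccc(Cl)c1`, gives 26.3 nM in this assay, and the step of a 1.6-fold higher number from compound 1 to compound 2 (0.21 log units; within the scatter) corresponds to chloro in place of hydrogen on an aromatic carbon. Compound 3, `Cc1c(NC2=NCCN2)cccc1-c1cccc(C(C)C)c1`, has not yet been measured; it differs from compound 1 by isopropyl in place of hydrogen on an aromatic carbon. Among the measured compounds shown here, the only measured step that bears on this change is the one in which a group likewise enters on an aromatic carbon of the same outer ring, a 1.6-fold higher number from compound 1 to compound 2 (0.21 log units; within the scatter), and that step stayed within the scatter. Since a chloro group entering there left the number essentially unchanged, an isopropyl group entering in the same way is expected to give a small shift at most, with some allowance for a larger group. Compound 3 is therefore expected to give 25 nM in this assay, between 8 nM and 80 nM, a step of a 1.5-fold higher number from compound 1 to compound 3 (0.19 log units; within the scatter) that is expected to remain within or near the scatter.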

Compound 3, inhibition constant: 182 nM
Estimate against measurement, compound 3: 7.3-fold (0.86 log units) below; the whole stated range lies below it.
By their numbers in this assay, from the lowest: compounds 1 and 2 (each within the scatter of the next); then compound 3.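

In this assay, this aromatic carbon, meta to a large group, does not treat all entering groups alike. Isopropyl in place of hydrogen gives a large loss (an 11-fold higher number from compound 1 to compound 3 (1.05 log units; beyond the scatter)), unlike chloro, and isopropyl in place of chloro also separates the two groups beyond the scatter (a 6.9-fold higher number from compound 2 to compound 3 (0.84 log units; beyond the scatter)), so the outcome at this position depends on which group enters. No measurement shown here accounts for the difference between isopropyl and chloro.

The three compounds leave open where between chloro and isopropyl the number begins to rise, and whether a methyl, a methoxy, a tert-butyl or an amine at this carbon would stay with compound 2 or move towards compound 3. They also leave open whether isopropyl would act the same way on another carbon of that ring.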